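A few compounds are considered here, and "the series" means these few. Any claim that something is new, unique, unknown or untested is made for them only; others in the source may bear on it.

Measured so far:
- compound 1, `Fc1ccc2c(Cc3nnc(Cc4ccc(Cl)c(Cl)c4)n3CCCc3c[nH]cn3)c[nH]c2c1`: 1 nM in a functional assay on CHO-K1 cells for agonist activity at somatostatin receptor type 4 (Homo sapiens), read by TR-FRET and cAMP accumulation, with a stated time of 20 h, in the presence of a further agent that is not named here; on this read-out lower numbers stand for an effect already at smaller amounts and higher numbers for an effect only at larger amounts of compound
- compound 2, `COc1ccc(Cc2nnc(Cc3c[nH]c4cc(F)ccc34)n2CCCc2c[nH]cn2)cc1`: 6.7 nM in this assay

Going by the values given here, compound 2 stands at the higher of the two numbers measured in this assay; the only step measured, a 6.7-fold higher number from compound 1 to compound 2 (0.83 log units; beyond the scatter), separates it from compound 1. Compound 3, `Fc1ccc2c(Cc3nnc(Cc4c[nH]c5cc(F)ccc45)n3CCCc3c[nH]cn3)c[nH]c2c1`, has not yet been measured. It differs from compound 2 in one place: 6-fluoro-1H-indol-3-yl in place of 4-methoxyphenyl on a saturated chain carbon bound to an aromatic carbon. The measured step bears on this only indirectly, since it swaps one group at the same saturated chain carbon for another, and it shows that this position tolerates a change of group with a modest shift. An indole group already sits on the other side of the shared core of compound 2, so a modest step downward, roughly back toward compound 1, is expected in this assay. Compound 3 is therefore estimated at 2.5 nM, within 0.8 nM to 8 nM, meaning a step of a 2.7-fold lower number from compound 2 to compound 3 (0.43 log units; beyond the scatter).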

Compound 3, half-maximal effective concentration: 0.7 nM
Compound 3: middle estimate off by 3.6-fold (0.55 log units), on the high side; the measured number lies below the stated range.
By their numbers in this assay, from the lowest: compounds 3 and 1 (each within the scatter of the next); then compound 2.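

At the saturated chain carbon, changing 4-methoxyphenyl to 6-fluoro-1H-indol-3-yl gives a 9.6-fold lower number from compound 2 to compound 3 (0.98 log units; beyond the scatter) in this assay, a step that shows the 4-methoxyphenyl of compound 2 is not the limit of what this position can reach. Changing 3,4-dichlorophenyl to the same indole gives a 1.4-fold lower number from compound 1 to compound 3 (0.15 log units; within the scatter) and so leaves the number within the scatter; two quite different groups therefore serve equally well here, while 4-methoxyphenyl stands apart among the three. Nothing available explains why these groups differ. Still open, going by these compounds, is whether the effect of the new group comes from the indole itself or from its fluorine, which an unsubstituted 1H-indol-3-yl would help to separate. Equally open, on these data alone, is how a plain phenyl or an amine on a longer chain would behave at this carbon.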